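The source may report more compounds than this note shows. Statements on the series, on what has been measured and on what is new or still open speak of the compounds shown alone.

Notes on the series so far. Among the compounds with values here, in a functional assay on MCF7 cells (Homo sapiens) for inhibition, read by fluorescence, with a stated time of 72 h (a lower number here means a stronger inhibitor of growth, a higher number a weaker inhibitor of growth), compound 1 (`CC(C)=CCn1cnc2c(Nc3cccc(Cl)c3)nc(N[C@H]3CC[C@H](N)CC3)nc21`) gives 4200 nM and is joined by only one other measured compound, compound 2 (`CCCCCCn1cnc2c(Nc3cc(OC)cc(OC)c3)nc(N[C@H]3CC[C@H](N)CC3)nc21`), which gives 3500 nM in the same read-out. These two values lie within the scatter of each other, so compound 1 holds no distinct place between them. Within the data shown here, the two compounds differ in more than one place, and no single-change step has been measured.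

Compound 3 (`CCCCn1cnc2c(Nc3cccc(Cl)c3)nc(N[C@H]3CC[C@H](N)CC3)nc21`) keeps the core of compound 1 and carries propyl in place of 2-methylprop-1-en-1-yl on a saturated chain carbon bound to an aromatic nitrogen. Cut one bond further out, the same difference reads 3-methylbut-2-en-1-yl to butyl.

In this assay no step beyond the scatter is expected, in either direction. This expectation rests on compound 2, which has a saturated chain at that place, gives 3500 nM and stays within the scatter of compound 1, although it differs elsewhere too. The estimated step (a 1.1-fold lower number from compound 1 to compound 3 (0.04 log units; within the scatter)) is expected to remain within the scatter. For compound 3 the estimated value is 3800 nM with an expected range from 1700 nM to 8000 nM in this read-out.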

Compound 3, concentration for 50% growth inhibition: 2000 nM
Estimate against measurement, compound 3: 1.9-fold (0.28 log units) above, and the stated range covers the measured number.
By their numbers in this assay, from the lowest: compounds 3, 2 and 1 (each within the scatter of the next, the first and the last beyond it).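

In this assay the series now has its first single-change step at the place on a saturated chain carbon bound to an aromatic nitrogen: a 2.1-fold lower number from compound 1 to compound 3 (0.32 log units; beyond the scatter) goes with propyl in place of 2-methylprop-1-en-1-yl, which reads 3-methylbut-2-en-1-yl to butyl when cut one bond further out. With the rest of compound 1 held fixed, this position therefore responds to the chain that sits on it, modestly but beyond the scatter, something the earlier pair could not show because those compounds differ in more than one place. The change removes the double bond and alters the shape of the chain in one move, and no measurement at hand accounts for the step.

Whether the loss of the double bond or the change in chain shape carries the step remains open, since a saturated branched chain such as 3-methylbutyl on the core of compound 1 is not among the compounds shown. Going by these compounds, it is also open how far this position tolerates other groups, such as a benzyl group, a cyclopentylmethyl group or a chain ending in a hydroxyl.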